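The compounds below may be only part of what the source reports. "The series", "measured", "known", "first", "only" and "open" are said of these compounds alone.

Compound 1 `O=S(=O)(NCCCCNCc1ccc(Br)cc1)c1cc(C(F)(F)F)cc(C(F)(F)F)c1` — 1600 nM
Compound 2 `O=S(=O)(NCCCNCC1COc2ccccc2O1)c1cc(C(F)(F)F)cc(C(F)(F)F)c1` — 2200 nM

Two compounds sharing a bis(trifluoromethyl)phenylsulfonamide core have been measured in a functional assay on HT-29 cells (Homo sapiens) for inhibition, read by MTT assay, with a stated time of 72 h; on this read-out lower numbers stand for stronger inhibition of growth and higher numbers for weaker inhibition of growth. Compound 1 gives 1600 nM in this assay, the lower of the two numbers, while compound 2 gives 2200 nM; the gap between them lies within the usual scatter, so neither can be called the more potent.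

Compound 3 `COc1ccc(CNCCCNS(=O)(=O)c2cc(C(F)(F)F)cc(C(F)(F)F)c2)cc1` is not yet measured. It differs from compound 1 in one place: (4-methoxybenzyl)amino in place of ((4-bromobenzyl)amino)methyl on a saturated chain carbon, three bonds along the chain from a sulfonamide nitrogen. Among the measured compounds shown here, the two measured compounds give no step that isolates this kind of change, so the direction of the effect cannot be read from the data. Given that both measured compounds sit close together, compound 3 is expected to land in the same region, with a step of a 1.6-fold higher number from compound 1 to compound 3 (0.19 log units; within the scatter) that may not exceed the scatter. Compound 3 is therefore estimated at 2500 nM in this assay, within a range of 1000 nM to 6500 nM.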

Compound 3, concentration for 50% growth inhibition: 2900 nM
Estimate against measurement, compound 3: 1.2-fold (0.06 log units) below, and the stated range covers the measured number.
By their numbers in this assay, from the lowest: compounds 1, 2 and 3 (each within the scatter of the next).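

In this assay, (4-methoxybenzyl)amino in place of ((4-bromobenzyl)amino)methyl on a saturated chain carbon, three bonds along the chain from a sulfonamide nitrogen, gives a 1.8-fold higher number from compound 1 to compound 3 (0.26 log units; within the scatter) and so does not separate these two groups. Likewise, 4-methoxyphenyl in place of 2,3-dihydro-1,4-benzodioxin-2-yl on a saturated chain carbon bound to an amine nitrogen gives a 1.3-fold higher number from compound 2 to compound 3 (0.12 log units; within the scatter) and leaves these two groups equally unseparated. Neither step goes beyond the scatter, and no measurement at hand bears on the reason for either.

The compounds shown leave open whether the methoxy group and the bromine differ when nothing else in the chain changes. They also leave open whether a carboxylic acid or an amide on this chain would give a number beyond the scatter.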